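Swapping the para methoxy for methyl on a sulfonamide hydroxamate

The compounds below may be only part of what the source reports. "The series", "measured", "known", "first", "only" and "open" are said of these compounds alone.

Compound 1, `COc1ccc(S(=O)(=O)N(CCN=[N+]=[N-])[C@@H](C(=O)NO)C(C)C)cc1`, gives 6 nM in an assay on isolated protein for inhibition of matrix metalloproteinase-9 (Homo sapiens), read by fluorescence, with a stated time of 30 min; on this read-out higher numbers stand for weaker inhibition and lower numbers for stronger inhibition.
Compound 2, `COc1ccc(S(=O)(=O)N(CCn2cc(COCCOCCOCCOCCOCCF)nn2)[C@@H](C(=O)NO)C(C)C)cc1`, gives 2 nM in this assay.

Compound 2 stands lowest of the two numbers; compound 1 shows a higher number, and that gap lies beyond the usual scatter. Compound 3, `Cc1ccc(S(=O)(=O)N(CCn2cc(COCCOCCOCCOCCOCCF)nn2)[C@@H](C(=O)NO)C(C)C)cc1`, differs from compound 2 only by methyl in place of methoxy on an aromatic carbon. For the measured compounds named here, no measured pair shows this kind of change, so its effect is not known from these data; a modest weakening seems the most likely outcome, possibly no larger than the scatter. Compound 3 is expected to give about 5 nM, within a range from 1.5 nM to 20 nM. That estimate corresponds to an expected step of a 2.5-fold higher number from compound 2 to compound 3 (0.40 log units; beyond the scatter).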

Compound 3, half-maximal inhibitory concentration: 0.4 nM
For compound 3 the middle estimate is 13-fold (1.10 log units) above the measured one; the whole stated range lies above it.
By their numbers in this assay, from the lowest: compound 3; then compound 2; then compound 1.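

On an aromatic carbon para to a large group, methyl in place of methoxy gives a 5.0-fold lower number from compound 2 to compound 3 (0.70 log units; beyond the scatter) in this assay. This position therefore responds to a one-group edit, and losing the methoxy oxygen, with its hydrogen-bond acceptor, costs no inhibition here. The data at hand offer no explanation for the gain.

Going by these compounds, whether the same change would act alike on compound 1, which carries a different chain, stays open. So does how a chloro or an ethyl group would fare at this position.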